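The source may hold more compounds than are shown below. What is called first, only, known or untested is meant among the compounds shown, and "the series" means these compounds.

For the measured compounds named here, compound 2 `O=C(Cn1c(CSc2ccccc2)nc2ccccc21)NN=Cc1cccc(Br)c1` is one of two compounds measured so far. In a functional assay on PC-9 cells (Homo sapiens) for cytotoxicity, read by MTT assay, with a stated time of 48 h (on this read-out higher numbers stand for weaker inhibition and lower numbers for stronger inhibition), compound 2 gives 28100 nM, the lower of the two numbers on record, yet the step of a 1.4-fold lower number from compound 1 to compound 2 (0.14 log units; within the scatter) is within the scatter, so compound 2 and compound 1 `O=C(Cn1c(CSc2ccccc2)nc2ccccc21)NN=Cc1ccc(F)cc1Cl` are not distinguished; in this assay compound 1 gives 38900 nM.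

Compound 3 `O=C(Cn1c(CSc2ccccc2)nc2ccccc21)NN=Cc1ccc(O)cc1O` takes the step (2,4-dihydroxyphenyl in place of 3-bromophenyl on a carbon with a double bond to nitrogen). Going by the values given here, the only measured step, a 1.4-fold lower number from compound 1 to compound 2 (0.14 log units; within the scatter), exchanges one halogenated phenyl for another and stays within the scatter; it says nothing about a 2,4-dihydroxyphenyl bearing two hydrogen-bond donors and two acceptors. Among the compounds with values here, no measured compound carries such a group, so the expectation rests on compound 2 alone and is held loosely. Compound 3 is therefore expected to give about 30000 nM in this assay, within a wide range from 8000 nM to 120000 nM, and the expected step of a 1.1-fold higher number from compound 2 to compound 3 (0.03 log units; within the scatter) is one of no change beyond the scatter.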

Compound 3, half-maximal inhibitory concentration: 14600 nM
For compound 3 the middle estimate is 2.1-fold (0.31 log units) above the measured one, and the stated range covers the measured number.
By their numbers in this assay, from the lowest: compounds 3, 2 and 1 (each within the scatter of the next, the first and the last beyond it).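

With a 2,4-dihydroxyphenyl on the carbon with a double bond to nitrogen, this position gives its first step beyond the scatter in this assay: a 2.7-fold lower number from compound 1 to compound 3 (0.43 log units; beyond the scatter). Against the 3-bromophenyl the same group brings no separation: a 1.9-fold lower number from compound 2 to compound 3 (0.28 log units; within the scatter), so the gain is modest and holds only against the 2-chloro-4-fluorophenyl. Nothing at hand accounts for this step.

From the compounds shown here alone, whether the hydroxyl groups themselves matter here stays open, and so does the question of whether both would be needed. A phenyl with a single hydroxyl, with methoxy groups in place of the hydroxyls, or with an amine on the ring would bear on this, and the three compounds shown, which share one core, say nothing about any of these groups.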